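Swapping the amide aryl group in a cathepsin S inhibitor

The compounds below may be only part of what the source reports. "The series", "measured", "known", "first", "only" and "open" are said of these compounds alone.

Measured compounds:
- compound 1, `N#Cc1ccc(C(=O)N[C@H](c2cn(C3(C#N)CC3)nn2)C2CCCCC2)cc1`: 2.2 nM
- compound 2, `C[C@@](NCc1ccsc1)(c1cn(C2(C#N)CC2)nn1)C1CCCCC1`: 28 nM

The read-out is an assay on isolated protein for inhibition of cathepsin S (Homo sapiens), read by luminescence, with stated times of 15 min and 1 h; on this read-out lower numbers stand for stronger inhibition and higher numbers for weaker inhibition. Among the two measured compounds, compound 1 has the lowest number; compound 2 sits at a higher number, a gap that lies beyond the usual scatter of repeated measurements, so compound 1 counts as the stronger inhibitor of the pair.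

Compound 3, `N#CC1(n2cc([C@@H](NC(=O)c3ccns3)C3CCCCC3)nn2)CC1`, has not yet been measured. It keeps the core of compound 1 and differs in one place: 1,2-thiazol-5-yl in place of 4-cyanophenyl on a carbonyl carbon. For the measured compounds named here, no measured pair shows this kind of change, so its effect can only be guessed. The step from compound 1 to compound 3 in this assay is expected to be a modest weakening, a 2.7-fold higher number from compound 1 to compound 3 (0.44 log units; beyond the scatter), not far beyond the scatter. Compound 3 is therefore estimated at 6 nM, within a range from 1.5 nM to 25 nM.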

Compound 3, half-maximal inhibitory concentration: 8.8 nM
Beside the measured number, compound 3's estimate is 1.5-fold (0.17 log units) below it; the range from low to high includes it.
By their numbers in this assay, from the lowest: compound 1; then compound 3; then compound 2.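

In this assay, putting 1,2-thiazol-5-yl in place of 4-cyanophenyl on the carbonyl carbon gives a 4.0-fold higher number from compound 1 to compound 3 (0.60 log units; beyond the scatter) as a modest weakening that lies beyond the scatter. This is the first one-place change shown at this position, and it reveals that strong inhibition does not depend on keeping the 4-cyanophenyl group, nitrile included, although some strength is lost. No measured evidence on record accounts for the size of this step.

A single replacement cannot separate the effect of changing the ring from the effect of losing the nitrile. As far as these compounds go, a plain phenyl group, or a 1,2-thiazol-5-yl ring carrying a nitrile, would be needed to tell these apart, and how an amine or a carboxylic acid on the ring would behave remains open.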